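A few compounds are considered here, and "the series" means these few. Any claim that something is new, unique, unknown or untested is made for them only; others in the source may bear on it.

Compound 1 `CC(C)(C)N(NC(=O)c1ccccc1)C(=O)c1ccccc1Cl` is the reference point of this small series. Among the measured compounds shown here, in an assay on cells for agonist activity at ecdysone receptor (Bombyx mori), read by a luciferase reporter, with a stated time of 24 h (on this read-out higher numbers stand for an effect only at larger amounts of compound and lower numbers for an effect already at smaller amounts), compound 1 gives 75.9 nM, the highest of the three numbers measured so far. Compound 2 `COc1cccc(C(=O)NN(C(=O)c2ccccc2Cl)C(C)(C)C)c1` carries a methoxy group on the same benzoyl ring and gives 52.5 nM in this assay; the step of a 1.4-fold lower number from compound 1 to compound 2 (0.16 log units; within the scatter) lies within the scatter. Compound 3 `CC(C)(C)N(NC(=O)c1ccc(I)cc1)C(=O)c1ccccc1Cl` carries an iodo group instead and gives 7.59 nM, a step of a 10-fold lower number from compound 1 to compound 3 (1.00 log units; beyond the scatter); between the two substituted analogues the step is a 6.9-fold lower number from compound 2 to compound 3 (0.84 log units; beyond the scatter).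

Compound 4 `CC(C)(C)N(NC(=O)c1cccc(Cl)c1Cl)C(=O)c1ccccc1Cl` differs from compound 1 in one place: 2,3-dichlorophenyl in place of phenyl on a carbonyl carbon. The two measured steps that bear on this change are both substitutions on the same benzoyl ring: the methoxy step a 1.4-fold lower number from compound 1 to compound 2 (0.16 log units; within the scatter) and the iodo step a 10-fold lower number from compound 1 to compound 3 (1.00 log units; beyond the scatter). For the measured compounds named here, neither of them places a substituent at the positions occupied in the 2,3-dichlorophenyl group, so they show only that this ring tolerates substitution, and in one case rewards it. Because of a 1.4-fold lower number from compound 1 to compound 2 (0.16 log units; within the scatter) and a 10-fold lower number from compound 1 to compound 3 (1.00 log units; beyond the scatter), compound 4 is expected to sit in the same general region as compound 1, with the step of a 1.4-fold higher number from compound 1 to compound 4 (0.16 log units; within the scatter) as the most likely outcome. The estimate for compound 4 in this assay is 110 nM, within a range from 30 nM to 400 nM.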

Compound 4, half-maximal effective concentration: 9.33 nM
Compound 4: middle estimate off by 12-fold (1.07 log units), on the high side; measured number outside the range, below it.
By their numbers in this assay, from the lowest: compounds 3 and 4 (each within the scatter of the next); then compounds 2 and 1 (each within the scatter of the next).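

In this assay, putting 2,3-dichlorophenyl in place of phenyl on the carbonyl carbon gives an 8.1-fold lower number from compound 1 to compound 4 (0.91 log units; beyond the scatter) and so shows that a clear change at this position is not confined to the 4-iodophenyl group of compound 3. The two groups cannot be told apart here, with a 1.2-fold higher number from compound 3 to compound 4 (0.09 log units; within the scatter) lying within the scatter, while the 3-methoxyphenyl group of compound 2 stays apart from the new group, with a 5.6-fold lower number from compound 2 to compound 4 (0.75 log units; beyond the scatter) and thus a step beyond the scatter. Among these four compounds, the two with halogen on this ring therefore form one group, and the compounds with phenyl and 3-methoxyphenyl form another; no measurement shown gives a reason for this split.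

The compounds shown leave open whether one of the two chlorine atoms alone would account for the step, since no analogue carries a single chloro group on this ring. They also leave open how this position would respond to a quite different substituent on the same ring, such as an amine or a carboxylic acid.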